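A few compounds are considered here, and "the series" means these few. Any claim that something is new, unique, unknown or untested is made for them only; others in the source may bear on it.

Working notes on the series. Compound 1, `O=C(NCc1cn(Cc2ccc(C(F)(F)F)cc2)nn1)c1cn(-c2ccccc2)nc1-c1ccccc1`, compound 2, `COc1ccc(Cn2cc(CNC(=O)c3cn(-c4ccccc4)nc3-c3ccccc3)nn2)cc1`, and compound 3, `COc1cc(Cn2cc(CNC(=O)c3cn(-c4ccccc4)nc3-c3ccccc3)nn2)cc(OC)c1OC`, share one core and differ only in the group on the saturated chain carbon bound to an aromatic nitrogen. In a functional assay on HeLa cells (Homo sapiens) for antiproliferative activity, read by sulforhodamine B assay, with a stated time of 48 h (on this read-out higher numbers stand for weaker inhibition of growth and lower numbers for stronger inhibition of growth), compound 1 gives 1600 nM and compound 2 gives 6900 nM. Compound 3 gives only > 100000 nM in this assay, which is a limit and not a number. Both an at least 62-fold higher number from compound 1 to compound 3 (1.79 log units; beyond the scatter) and an at least 14-fold higher number from compound 2 to compound 3 (1.16 log units; beyond the scatter) run into that limit (the limit of > 100000 nM in this assay, at which 1 of the 3 values shown sits). Compound 4, `COc1ccc(-c2nn(-c3ccccc3)cc2C(=O)NCc2cn(Cc3cc(OC)c(OC)c(OC)c3)nn2)cc1`, differs from compound 3 by methoxy in place of hydrogen on an aromatic carbon. Going by the values given here, no measured step touches that phenyl; all three concern the 3,4,5-trimethoxyphenyl arm, which compound 4 keeps. The step that the limit leaves unreadable from compound 3 to compound 4 is therefore expected to stay within the scatter. Compound 4 is estimated at 150000 nM, within 50000 nM to 500000 nM, most probably again reported as a limit.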

Compound 4, concentration for 50% growth inhibition: 1700 nM
Compound 4: middle estimate off by 88-fold (1.95 log units), on the high side, and the stated range ends above it.
By their numbers in this assay, from the lowest: compounds 1 and 4 (each within the scatter of the next); then compound 2. At a limit, above all of these: compound 3.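

Going by these compounds alone, the change from phenyl to 4-methoxyphenyl, at a place no earlier step touched, gives an at least 58-fold lower number from compound 3 to compound 4 (1.76 log units; beyond the scatter) in this assay. The 3,4,5-trimethoxyphenyl arm therefore does not by itself rule out growth inhibition, since compound 4 keeps it and gives 1700 nM. Compound 3 gives > 100000 nM, a limit and not a number, so the step has no exact size: the limit of > 100000 nM in this assay, at which 1 of the 4 values shown sits.

As far as these compounds go, whether this methoxy also lowers the number with the arms of compound 1 or compound 2 stays open. So does whether a hydroxy, a fluorine or a dimethylamino group serves in its place.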